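Swapping Diethylamino for Ethoxy on an Active Ester

This account rests on a few compounds, and the source may have more. Where it says the series, first, only, none or still open, it means among the compounds named here.

In a functional assay on NCI-H727 cells (Homo sapiens) for antiproliferative activity, with a stated time of 48 h (on this read-out higher numbers stand for weaker inhibition and lower numbers for stronger inhibition), compound 1 `CCN(CC)c1ccc(-c2ccc(C#N)cc2)nn1` gives > 25000 nM, which is a limit of the assay and not a number. Among the compounds with values here, compound 2 `CCOC(=O)c1ccc(-c2ccc(N(CC)CC)nn2)cc1` gives 1500 nM, the only true number so far. Compound 3 `CCOC(=O)c1ccc(-c2ccc(OCC)nn2)cc1` differs from it as follows: ethoxy in place of diethylamino on an aromatic carbon. Within the data shown here, the one measured step, an at least 16-fold lower number from compound 1 to compound 2 (1.22 log units; beyond the scatter), was large, but it put ethoxycarbonyl in place of cyano and kept the diethylamino group, so it gives little guidance here. Only a small step toward weaker inhibition is expected, a 2.0-fold higher number from compound 2 to compound 3 (0.30 log units; within the scatter). For compound 3 the estimate is 3000 nM, with an expected range of 800 nM to 15000 nM.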

Compound 3, half-maximal inhibitory concentration: > 25000 nM
Compound 3: no number, only a limit (the forecaster's own chance of this, stated with the estimate: 15%); middle value at least 8.3-fold (0.92 log units) away from the limit.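

With the ester kept, the diethylamino group proves to matter as well: ethoxy in its place on this aromatic carbon, next to the ring nitrogen, gives an at least 16-fold higher number from compound 2 to compound 3 (1.22 log units; beyond the scatter) in this assay. Of the compounds shown, only compound 2, which carries both ethoxycarbonyl and diethylamino, gives a true number. Compound 3 has only a limit of the assay, not a number, and the full size of its step stays unknown: the limit of > 25000 nM in this assay, at which 2 of the 3 values shown sit.

Still open, on these data alone, is whether the nitrogen itself is what counts here, or the two ethyl chains on it. A dimethylamino group, a piperidine or a longer chain on the nitrogen would test this.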